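Trimming the (4-Methylphenyl)carbonyl Arm in a Cytotoxicity Series

The source may report more compounds than this note shows. Statements on the series, on what has been measured and on what is new or still open speak of the compounds shown alone.

Compound 1, `Cc1ccc(C(=O)CSc2nnc(C)n2N2C(=O)c3ccccc3C2=O)cc1`: > 200000 nM
Compound 2, `CSc1nnc(C)n1N1C(=O)c2ccccc2C1=O`: > 200000 nM
Compound 3, `CCc1nnc(SCC(=O)c2ccc(C)cc2)n1N1C(=O)c2ccccc2C1=O`: > 200000 nM

All three compounds were tested in a functional assay on MKN-45 cells (Homo sapiens) for cytotoxicity, read by MTT assay, with a stated time of 48 h; a lower number here means a stronger inhibitor, a higher number a weaker inhibitor. For compound 1 the reading is a limit of the assay, not a number. For compound 2 the reading is likewise a limit. For compound 3 the reading is a limit as well. The shared picture is captured by the limit of > 200000 nM in this assay, at which 3 of the 3 values shown sit.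

Compound 1 and compound 2 differ by hydrogen in place of (4-methylphenyl)carbonyl on a saturated chain carbon bound to a sulfur. Both readings are limits. The step that the two limits leave unreadable from compound 1 to compound 2 cannot be sized. Compound 1 and compound 3 differ in their cores by methyl in place of hydrogen on a saturated chain carbon bound to an aromatic carbon, and the step that the two limits leave unreadable from compound 1 to compound 3 is equally unreadable.

Compound 4, `CCc1nnc(SC)n1N1C(=O)c2ccccc2C1=O`, has not yet been measured. It differs from compound 3 by hydrogen in place of (4-methylphenyl)carbonyl on a saturated chain carbon bound to a sulfur. This is the same change that turns compound 1 into compound 2, made on the core of compound 3 instead. The expected step that the limit leaves unreadable from compound 3 to compound 4 is that compound 4 stays where its three relatives sit, an expectation resting on the unreadable step that the two limits leave unreadable from compound 1 to compound 2 and on (the limit of > 200000 nM in this assay, at which 3 of the 3 values shown sit), which give no sign that any of these compounds reaches a measurable number.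

The estimate for compound 4 is 300000 nM. The estimated range for compound 4 runs from 100000 nM to 1000000 nM.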

Compound 4, half-maximal inhibitory concentration: > 200000 nM
Compound 4 ended at the assay's limit; the forecaster's own chance of this, stated with the estimate: 85%; the middle value lies beyond the limit too.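

Compound 4 gives a limit of the assay and not a number, as do compound 2 and compound 3, and the steps to compound 4 from compound 3 and from compound 2 cannot be read. All four compounds share one reading: the limit of > 200000 nM in this assay, at which 4 of the 4 values shown sit. The compounds shown leave open how far each true value lies past that limit, and whether any change to the shared core would give a measurable number.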